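This account rests on a few compounds, and the source may have more. Where it says the series, first, only, none or still open, it means among the compounds named here.

Compound 1 `CC(c1cc2cccnc2cc1F)n1cnc2ncc(-c3ccncc3)nc21` gives 171 nM in a functional assay on NCI-H1993 cells (Homo sapiens) for inhibition, read by CCK-8 assay, with a stated time of 72 h (on this read-out lower numbers stand for stronger inhibition and higher numbers for weaker inhibition), the highest of the two numbers in hand; its nearest neighbour, compound 2 `CC(c1c(F)cc2ncccc2c1F)n1cnc2ncc(-c3ccncc3)nc21`, gives 162 nM, and the step of a 1.1-fold lower number from compound 1 to compound 2 (0.02 log units; within the scatter) is a fluoro in place of hydrogen on an aromatic carbon. Compound 3 `CC(c1cc2cccnc2cc1F)n1cnc2ncc(-c3cnc4ccccc4c3)nc21` differs from compound 1 by quinolin-3-yl in place of pyridin-4-yl on an aromatic carbon. Going by the values given here, no measured step touches this position, so the fluoro step offers no guide here. Compound 3 is therefore expected to lie close to compound 1, with a wide range, at 120 nM (between 30 nM and 500 nM), a step of a 1.4-fold lower number from compound 1 to compound 3 (0.15 log units; within the scatter).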

Compound 3, half-maximal inhibitory concentration: 109 nM
Compound 3: the middle estimate sits 1.1-fold (0.04 log units) above what was measured; the measured number falls inside the stated range.
By their numbers in this assay, from the lowest: compounds 3, 2 and 1 (each within the scatter of the next).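

Quinolin-3-yl in place of pyridin-4-yl, on the aromatic carbon next to the ring nitrogen, gives a 1.6-fold lower number from compound 1 to compound 3 (0.20 log units; within the scatter) in this assay. Going by these compounds alone, this is the first measured change at this position, and it shows that an added six-membered aromatic ring of carbon only leaves the value within the scatter. Nothing measured on these compounds bears on why this is so. Still open, going by these compounds, is whether an amine or a carboxylic acid on the quinolin-3-yl, or a morpholine at this position, would move the value beyond the scatter.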